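Methyl-to-hydrogen removal on the chain of a nitro analogue

The source may hold more compounds than are shown below. What is called first, only, known or untested is meant among the compounds shown, and "the series" means these compounds.

Measured so far:
compound 1 `CCc1cc(C(=O)N[C@H](C)CCCc2cccnc2)ccc1-c1ccc(OC)c(OC)c1`, 4 nM
compound 2 `CCCc1cc(C(=O)N[C@H](C)CCCc2cccnc2)ccc1-c1ccc(OC)c(OC)c1`, 50 nM
compound 3 `COc1ccc(-c2ccc(C(=O)N[C@H](C)CCCc3cccnc3)cc2[N+](=O)[O-])cc1OC`, 200 nM

All three were tested in an assay (Canis lupus familiaris) for binding affinity to platelet-activating factor receptor (Homo sapiens), read by radioligand binding; on this read-out lower numbers stand for stronger inhibition and higher numbers for weaker inhibition. The cores of compound 2 and compound 3 differ by nitro in place of propyl on an aromatic carbon, a change that gave a 4.0-fold higher number from compound 2 to compound 3 (0.60 log units; beyond the scatter). Between compound 1 and compound 3 the change is nitro in place of ethyl, with a 50-fold higher number from compound 1 to compound 3 (1.70 log units; beyond the scatter). Within the ethyl/propyl pair the change hydrogen in place of methyl on a saturated chain carbon, two bonds along the chain from an aromatic carbon gave a 13-fold lower number from compound 2 to compound 1 (1.10 log units; beyond the scatter).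

Compound 4 `COc1ccc(-c2ccc(C(=O)NCCCCc3cccnc3)cc2[N+](=O)[O-])cc1OC` is not yet measured. It differs from compound 3 by hydrogen in place of methyl on a saturated chain carbon bound to an amide-type nitrogen and a saturated chain carbon. This is the same kind of change as that from compound 2 to compound 1, but at a different place: there the carbon was two bonds along the chain from an aromatic carbon, here it is bound to an amide-type nitrogen and a saturated chain carbon. A step of a 1.3-fold lower number from compound 3 to compound 4 (0.12 log units; within the scatter) is therefore expected, smaller than the earlier one, because the earlier 13-fold lower number from compound 2 to compound 1 (1.10 log units; beyond the scatter) concerned a different position and no shown pair tests this one. Compound 4 is estimated at 150 nM, within 40 nM to 600 nM.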

Compound 4, half-maximal inhibitory concentration: 200 nM
Compound 4: middle estimate off by 1.3-fold (0.12 log units), on the low side, within the range that was stated.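

In this assay, hydrogen in place of methyl gave no change at the digits printed from compound 3 to compound 4 (within the scatter), so this change does not carry from one core to another as a fixed step: the same change on two cores in this assay, a 13-fold lower number (1.10 log units; beyond the scatter) from compound 2 to compound 1 and no change at the digits printed (within the scatter) from compound 3 to compound 4, 13-fold (1.10 log units) apart, beyond the scatter of two such steps.
The two steps differ in place as well as in core, one lying two bonds along the chain from an aromatic carbon and the other on a saturated chain carbon bound to an amide-type nitrogen and a saturated chain carbon, so the gap cannot be assigned to either difference. With one pair on each side, no rule for the series follows.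

Open, on these data alone, is how the same methyl removal on the amide-bound chain reads on the core of compound 1. Also open, as far as these compounds go, is how an amine in place of the nitro group reads on the core of compound 4.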